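Chloro in Place of Bromo on a Shared Core

A few compounds are considered here, and "the series" means these few. Any claim that something is new, unique, unknown or untested is made for them only; others in the source may bear on it.

compound 1 `CCOc1ccc(/C=N/NC(=O)COc2cccc3ccccc23)cc1O` — 100 ug/mL
compound 2 `O=C(COc1cccc2ccccc12)N/N=C/c1ccccc1Br` — >= 20 ug/mL

Compound 1 `CCOc1ccc(/C=N/NC(=O)COc2cccc3ccccc23)cc1O` gives 100 ug/mL in an ADME assay on HEL cells (Homo sapiens) for cytotoxicity; a higher number here means that more compound is tolerated, a lower number that less compound is tolerated. For compound 2 `O=C(COc1cccc2ccccc12)N/N=C/c1ccccc1Br` the result in this assay is only a limit, >= 20 ug/mL, so its true value is not pinned down. This is the limit of >= 20 ug/mL in this assay, at which 1 of the 2 values shown sits. Compound 3 `O=C(COc1cccc2ccccc12)N/N=C/c1ccccc1Cl` differs from compound 2 by chloro in place of bromo on an aromatic carbon. For the measured compounds named here, no measured step between related compounds is available to lean on, so the step that the limit leaves unreadable from compound 2 to compound 3 is expected to be small, within the scatter. Compound 3 is estimated at 40 ug/mL, between 20 ug/mL and 100 ug/mL.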

Compound 3, minimum cytotoxic concentration: 100 ug/mL
Beside the measured number, compound 3's estimate is 2.5-fold (0.40 log units) below it; low and high end bracket the measured number.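

Compound 2 has only a limit, so no size can be read for its step to compound 3 in this assay: the limit of >= 20 ug/mL in this assay, at which 1 of the 3 values shown sits.

On these data alone, whether chloro in place of bromo on this shared core changes the tolerated concentration in this assay stays open.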